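The compounds below may be only part of what the source reports. "The series", "measured", "known", "first", "only" and "open" are said of these compounds alone.

In a functional assay on HeLa cells (Homo sapiens) for antiproliferative activity, read by XTT assay, with a stated time of 72 h (a lower number here means a stronger inhibitor, a higher number a weaker inhibitor), compound 1 (`C=C(C)CCC[C@]1(C)C2=CCC[C@](C)(CC(=O)c3ccoc3)[C@H]2CC[C@H]1C`) gives > 100000 nM, which is a limit of the assay and not a number. Compound 2 (`C=C(C)CCC[C@]1(C)C2=CCC[C@](C)(C[C@@H](O)C3=CC(=O)OC3O)[C@H]2CC[C@H]1C`) gives 2600 nM and compound 3 (`C=C(C)CCC[C@]1(C)C2=CCC[C@](C)(C[C@H](O)C3=CC(=O)OC3O)[C@H]2CC[C@H]1C`) gives 3800 nM. These two differ only in one stereocentre, and a 1.5-fold higher number from compound 2 to compound 3 (0.16 log units; within the scatter), so compound 3 stands level with compound 2 and far from compound 1.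

The next structure, compound 4 (`C=C(C)CCC[C@]1(C)C2=CCC[C@](C)(C[C@@H](O)c3ccoc3)[C@H]2CC[C@H]1C`), makes this change: a group of 7 heavy atoms (5 carbon, 2 oxygen; one five-membered aromatic ring with 1 hetero atom) in place of a group of 9 heavy atoms (5 carbon, 4 oxygen; one five-membered non-aromatic ring with 1 hetero atom), on a saturated chain carbon bound to a saturated ring carbon. It brings back the five-membered aromatic ring of compound 1, though the entering (furan-3-yl)(hydroxy)methyl group keeps a hydroxy group where compound 1 has a carbonyl.

The closest measured evidence runs in the opposite direction: an at least 26-fold lower number from compound 1 to compound 3 (1.42 log units; beyond the scatter), and likewise an at least 38-fold lower number from compound 1 to compound 2 (1.58 log units; beyond the scatter). Both sizes rest on (the limit of > 100000 nM in this assay, at which 1 of the 3 values shown sits). A large rise in the number is therefore expected, with a 16-fold higher number from compound 3 to compound 4 (1.20 log units; beyond the scatter) as the estimated step. The assay may well report only a limit again. For compound 4 the estimated value is 60000 nM, within an expected range from 12000 nM to 150000 nM.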

Compound 4, half-maximal inhibitory concentration: 59400 nM
For compound 4 the middle estimate is 1.0-fold (0.00 log units) above the measured one, and the stated range covers the measured number.
By their numbers in this assay, from the lowest: compounds 2 and 3 (each within the scatter of the next); then compound 4. At a limit, above all of these: compound 1.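

In this assay, the larger non-aromatic ring group gives way to (furan-3-yl)(hydroxy)methyl with a 16-fold higher number from compound 3 to compound 4 (1.19 log units; beyond the scatter) and a 23-fold higher number from compound 2 to compound 4 (1.36 log units; beyond the scatter), so the large rise also appears when a hydroxy group is kept on this saturated chain carbon, and a carbonyl is not needed for it. Compound 1 gives only a limit of the assay: the limit of > 100000 nM in this assay, at which 1 of the 4 values shown sits. Its step, an at least 1.6-fold lower number from compound 1 to compound 4 (0.22 log units; that floor lies within the scatter), has a floor within the scatter, so it cannot show whether hydroxy in place of carbonyl changes the number.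

The whole ring group changes at once, which leaves open which of its parts matters: the ring hydroxy, the ring carbonyl or the ring itself. Also open, as far as these compounds go, is how an amine or a carboxylic acid at this place would read, and how the furan compound with the other hydroxy configuration would compare.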